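The compounds below may be only part of what the source reports. "The series", "measured", "known", "first", "only" and "open" are said of these compounds alone.

Measured so far:
- compound 1, `COc1cc(/C=N/NC(=O)CCCc2nc3ccccc3c(=O)[nH]2)cc(O)c1O`: 50000000 nM
- compound 2, `O=C(CCc1nc2ccccc2c(=O)[nH]1)N/N=C/c1ccc(Cl)cc1`: 185000000 nM
- compound 3, `O=C(CCc1nc2ccccc2c(=O)[nH]1)N/N=C/c1ccc([N+](=O)[O-])cc1`: 220000000 nM

All three compounds share the same core and were tested in a physicochemical assay, read by spectrophotometry, with a stated time of 6 min; on this read-out lower numbers stand for stronger inhibition and higher numbers for weaker inhibition. Compound 1 gives the lowest of the three numbers, and its gaps to compound 2 and to compound 3 are both beyond the usual scatter, so it stands as the strongest inhibitor of the set. Compound 2 and compound 3 differ only in the group on their aryl ring, and the step of a 1.2-fold higher number from compound 2 to compound 3 (0.08 log units; within the scatter) lies within the scatter, so no ordering between them can be read.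

Compound 4, `O=C(CCCc1nc2ccccc2c(=O)[nH]1)N/N=C/c1ccc(O)c(O)c1`, differs from compound 1 in one place: hydrogen in place of methoxy on an aromatic carbon. Among the compounds with values here, no measured step removes a methoxy, and the only measured single-point change, a 1.2-fold higher number from compound 2 to compound 3 (0.08 log units; within the scatter), concerns a different kind of group on a differently substituted ring; it was small. With nothing measured that points in either direction, the change from compound 1 to compound 4 is expected to stay within the scatter, and the expected step is a 1.2-fold higher number from compound 1 to compound 4 (0.08 log units; within the scatter). On that basis compound 4 is expected to give about 60000000 nM in this assay, with a range from 20000000 nM to 180000000 nM.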

Compound 4, half-maximal inhibitory concentration: 50000000 nM
Compound 4: middle estimate off by 1.2-fold (0.08 log units), on the high side; the range from low to high includes it.
By their numbers in this assay, from the lowest: compounds 1 and 4 (each within the scatter of the next); then compounds 2 and 3 (each within the scatter of the next).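

In this assay, removing the methoxy group from its aromatic carbon and leaving a hydrogen atom there gives no change at the digits printed from compound 1 to compound 4 (within the scatter). Within the data shown here, this is the first measured step at this position, which is ortho to a hydroxy group, meta to a second hydroxy group and meta to a large group, and it shows that losing the methoxy group's 2 heavy atoms and its hydrogen-bond acceptor leaves no difference that this read-out can detect, whereas the only earlier step, chloro to nitro, concerned a different place on a different ring. No outside measurement on these compounds helps to interpret this result.

Still open, as far as these compounds go, is whether this position would accept other groups as readily, for example an ethoxy group, an amine or a carboxylic acid, since methoxy and hydrogen are only two of many possible occupants. Also open, from the compounds shown here alone, is what the two hydroxy groups contribute, as a compound carrying a methoxy group or a hydrogen atom in place of either one would be needed to test that.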